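Sulfamoyl in Place of Ethyl: Expecting a Lower Number

A few compounds are considered here, and "the series" means these few. Any claim that something is new, unique, unknown or untested is made for them only; others in the source may bear on it.

In a functional assay for inhibition, with Homo sapiens as the target (on this read-out higher numbers stand for weaker inhibition and lower numbers for stronger inhibition), the measured compounds stand as follows:
compound 1 `CN(C)c1cccc(Nc2nccc(-c3ccccn3)n2)c1`: 400 nM
compound 2 `NS(=O)(=O)c1cccc(Nc2nccc(-c3cccnc3)n2)c1`: 200 nM
compound 3 `CCc1cccc(Nc2nccc(-c3ccccn3)n2)c1`: 1400 nM

Compound 3 has the highest number of the three in this assay; compound 1 lies nearest to it, and compound 2 furthest, each beyond the scatter. The next compound, compound 4 `NS(=O)(=O)c1cccc(Nc2nccc(-c3ccccn3)n2)c1`, differs from compound 3 by one change: sulfamoyl in place of ethyl on an aromatic carbon.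

Within the data shown here, only one measured step bears on this position. It is a 3.5-fold higher number from compound 1 to compound 3 (0.54 log units; beyond the scatter), which shows that what sits at this place moves the number beyond the scatter. Among the measured compounds shown here, no step connects compound 2 to compound 4, as the two differ elsewhere as well; yet compound 2, which carries sulfamoyl at this same place, gives 200 nM in this assay, well below compound 3. For compound 4 a lower number than compound 3 is therefore expected, a step of about a 5.6-fold lower number from compound 3 to compound 4 (0.75 log units; beyond the scatter). The estimate for compound 4 in this assay is 250 nM, with a range of 80 nM to 800 nM.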

Compound 4, half-maximal inhibitory concentration: 500 nM
Beside the measured number, compound 4's estimate is 2.0-fold (0.30 log units) below it; the range from low to high includes it.
By their numbers in this assay, from the lowest: compounds 2, 1 and 4 (each within the scatter of the next, the first and the last beyond it); then compound 3.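

In this assay, sulfamoyl in place of ethyl gives a 2.8-fold lower number from compound 3 to compound 4 (0.45 log units; beyond the scatter) at this aromatic carbon, while sulfamoyl in place of dimethylamino gives a 1.3-fold higher number from compound 1 to compound 4 (0.10 log units; within the scatter) and so leaves these two groups undistinguished, with ethyl alone standing apart among the three. The earlier compounds shown here could not show that the other place matters too: pyridin-2-yl in place of pyridin-3-yl gives a 2.5-fold higher number from compound 2 to compound 4 (0.40 log units; beyond the scatter) and so the value of compound 2 did not carry over unchanged with sulfamoyl held constant. Nothing available explains the size of any of these steps.

On these data alone, whether a carboxylic acid, an amine or a longer chain at this place would fall with ethyl or with sulfamoyl and dimethylamino remains open. As far as these compounds go, it is also open whether the step between pyridin-2-yl and pyridin-3-yl keeps its size when ethyl or dimethylamino takes the place of sulfamoyl.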